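Smaller alkyl in place of cyclohexyl on the shared core

A few compounds are considered here, and "the series" means these few. Any claim that something is new, unique, unknown or untested is made for them only; others in the source may bear on it.

Compound 1 `CC(C)n1nc(-c2cc(C3CCCCC3)on2)c2c(N)ncnc21` and compound 2 `Cn1nc(-c2cc(C3CC3)on2)c2c(N)ncnc21` share one core and differ in two places. In an assay on BaF3 cells for inhibition of proto-oncogene tyrosine-protein kinase receptor Ret variant V804M (Homo sapiens), read by MTT assay, with a stated time of 48 h (on this read-out higher numbers stand for weaker inhibition of growth and lower numbers for stronger inhibition of growth), compound 1 gives 4730 nM, and compound 2 gives 5560 nM; the two numbers sit within the scatter of each other, so compound 1 stands level with compound 2 rather than apart from it, and both are weak. Compound 3 `CCc1cc(-c2nn(C(C)C)c3ncnc(N)c23)no1` carries ethyl in place of cyclohexyl on an aromatic carbon. For the measured compounds named here, no measured pair shows this change on its own; the step is expected to be none beyond the scatter, or a modest move toward weaker inhibition. Compound 3 is estimated at 6500 nM, with a range of 2500 nM to 17000 nM. The expected step is a 1.4-fold higher number from compound 1 to compound 3 (0.14 log units; within the scatter).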

Compound 3, concentration for 50% growth inhibition: 5770 nM
Beside the measured number, compound 3's estimate is 1.1-fold (0.05 log units) above it; low and high end bracket the measured number.
By their numbers in this assay, from the lowest: compounds 1, 2 and 3 (each within the scatter of the next).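

Ethyl in place of cyclohexyl on an aromatic carbon, next to the ring oxygen, is the first change at this position that can be read on its own, and in this assay it gives a 1.2-fold higher number from compound 1 to compound 3 (0.09 log units; within the scatter). Losing the non-aromatic ring therefore leaves compound 3 level with compound 1, and both remain weak. No supporting data bear on this result.

Going by these compounds, whether an amine or a carboxylic acid at this carbon would also leave the number level stays open. So does the effect of a phenyl ring there.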